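Thiazolidine amide series: aryl variation at the ring carbon

The source may report more compounds than this note shows. Statements on the series, on what has been measured and on what is new or still open speak of the compounds shown alone.

Compound 1 `CCCCCCCCCCCCCCCCCCNC(=O)[C@H]1CSC(c2ccc(Br)cc2)N1` and compound 2 `CCCCCCCCCCCCCCCCCCNC(=O)[C@H]1CSC(c2ccc(C#N)cc2)N1` share one core and differ only in the aryl group. In a functional assay on DU-145 cells (Homo sapiens) for antiproliferative activity, read by sulforhodamine B assay (a lower number here means a stronger inhibitor, a higher number a weaker inhibitor), compound 1 gives 13800 nM. For compound 2 this assay reports only a limit, > 20000 nM. The change from compound 1 to compound 2 shows an at least 1.4-fold higher number from compound 1 to compound 2 (0.16 log units; that floor lies within the scatter), which says no more than that compound 2 sits at the limit of > 20000 nM in this assay, at which 1 of the 2 values shown sits. Compound 2 therefore stands at the weak end of the two values shown, without a number of its own.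

Compound 3 `CCCCCCCCCCCCCCCCCCNC(=O)[C@H]1CSC(c2cc(F)cc(F)c2)N1` differs from compound 2 by 3,5-difluorophenyl in place of 4-cyanophenyl on a saturated ring carbon. Within the data shown here, the only measured step, an at least 1.4-fold higher number from compound 1 to compound 2 (0.16 log units; that floor lies within the scatter), bears on it loosely: it also exchanges one aryl substituent for another and stays within the scatter. Among the measured compounds shown here, no measured step changes the substitution pattern on the ring. The step of an at least 1.2-fold lower number from compound 2 to compound 3 (0.09 log units; that floor lies within the scatter) is expected to be small. Compound 3 is estimated at 16000 nM in this assay, within 7000 nM to 40000 nM.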

Compound 3, half-maximal inhibitory concentration: > 20000 nM
Compound 3: only a limit was reported; the forecaster's own chance of this, stated with the estimate: 45%; middle value at least 1.2-fold (0.09 log units) away from the limit.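

In this assay compound 3 carries only a limit, > 20000 nM. The 3,5-difluorophenyl group thus joins the 4-cyanophenyl group without a number of its own, and the step between these two cannot be read; against the 4-bromophenyl group, the change gives an at least 1.4-fold higher number from compound 1 to compound 3 (0.16 log units; that floor lies within the scatter), so a change in the substitution pattern on the aryl ring also yields only a floor. The limit now holds most of the series shown: the limit of > 20000 nM in this assay, at which 2 of the 3 values shown sit.

On these data alone, how far compound 2 and compound 3 lie past the limit stays open, as does any order between them. Also open, as far as these compounds go, is whether an amine or a carboxylic acid on the aryl ring would give a value inside the range of this assay.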